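Terminal carboxy in place of ethyl on the nonyl chain

The source may hold more compounds than are shown below. What is called first, only, known or untested is meant among the compounds shown, and "the series" means these compounds.

The series rests on a shared core carrying two phenyl groups and an alkyl chain on the aromatic nitrogen. Compound 1 `CCCCCCn1nc(-c2ccccc2)c(-c2ccccc2)cc1=O` gives 57000 nM in an assay on microsomes from liver for inhibition of sterol O-acyltransferase 1 (Rattus norvegicus); on this read-out higher numbers stand for weaker inhibition and lower numbers for stronger inhibition. Compound 2 `CCCCCCCCCn1nc(-c2ccccc2)c(-c2ccccc2)cc1=O` gives 85000 nM. Within the data shown here, the single measured step, a 1.5-fold higher number from compound 1 to compound 2 (0.17 log units; within the scatter), lies within the scatter, so compound 2 stands on the higher of two numbers without being set apart from compound 1.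

Compound 3 `O=C(O)CCCCCCCn1nc(-c2ccccc2)c(-c2ccccc2)cc1=O` differs from compound 2 by carboxy in place of ethyl on a saturated chain carbon, seven bonds along the chain from an aromatic nitrogen. Among the measured compounds shown here, no measured step involves a carboxy group or any hydrogen-bond donor or acceptor on the chain; the only step on record changes chain length and is within the scatter. The data therefore give no measured basis for a direction, and the expectation is at most a modest step beyond the scatter, if any. The change the estimate means is expected to be a 1.2-fold higher number from compound 2 to compound 3 (0.07 log units; within the scatter). For compound 3 the expected value is 100000 nM, with a range from 30000 nM to 350000 nM, the upper end allowing that this assay may report only a limit.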

Compound 3, half-maximal inhibitory concentration: > 300000 nM
Compound 3: only a limit was reported; the forecaster's own chance of this, stated with the estimate: 30%; middle value at least 3.0-fold (0.47 log units) from the limit.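

In this assay, among these compounds, the saturated chain carbon seven bonds along the chain from an aromatic nitrogen proves sensitive to what it carries: carboxy in place of ethyl gives an at least 3.5-fold higher number from compound 2 to compound 3 (0.54 log units; beyond the scatter), whereas the only earlier step, a 1.5-fold higher number from compound 1 to compound 2 (0.17 log units; within the scatter), did not separate the two alkyl compounds. Read from the other alkyl compound, carboxymethyl in place of hydrogen gives an at least 5.2-fold higher number from compound 1 to compound 3 (0.72 log units; beyond the scatter), so both new steps point toward weaker inhibition and both lie beyond the scatter. Compound 3 stands at a limit and not at a number, so the two steps give only a lower bound on the size of the change, because the reported value is that limit: the limit of > 300000 nM in this assay, at which 1 of the 3 values shown sits.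

As far as these compounds go, whether the change belongs to the carboxy group itself stays open, and a methyl ester or a primary amide at the same place, or a carboxylic acid on a shorter chain such as 3-carboxypropyl, would bear on that. Also open, from the compounds shown here alone, is how an amine at this place, or an alkyl chain longer than nonyl, would read in this assay.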